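Swapping the anilide ring of compound 3 for a 4-methoxyphenyl

The source may hold more compounds than are shown below. What is called first, only, known or untested is meant among the compounds shown, and "the series" means these compounds.

Among the compounds with values here, compound 3 `O=C(Nc1ccccc1F)N[C@H]1CC[C@H](Oc2ccc(F)cc2)CC1` is the only member of this small set to return a number in a functional assay on CRL2813 cells (Homo sapiens) for cytotoxicity, read by sulforhodamine B assay, with a stated time of 5 days; on this read-out lower numbers stand for stronger inhibition and higher numbers for weaker inhibition: compound 3 gives 17500 nM. Compound 1 `CSc1ccccc1NC(=O)N[C@H]1CC[C@H](Oc2ccc(F)cc2)CC1` reaches only a limit, for compound 1 reads > 20000 nM. Compound 2 `CSc1ccc(NC(=O)N[C@H]2CC[C@H](Oc3ccc(F)cc3)CC2)cc1` also stops at a limit, since compound 2 reads > 20000 nM. Two of the three values therefore sit at the limit of > 20000 nM in this assay, at which 2 of the 3 values shown sit. The step from compound 1 to compound 2 is a step that the two limits leave unreadable from compound 1 to compound 2, whereas an at least 1.1-fold lower number from compound 1 to compound 3 (0.05 log units; that floor lies within the scatter) and an at least 1.1-fold lower number from compound 2 to compound 3 (0.05 log units; that floor lies within the scatter) are both readable only as floors that lie within the scatter. Compound 4 `COc1ccc(NC(=O)N[C@H]2CC[C@H](Oc3ccc(F)cc3)CC2)cc1` differs from compound 3 by 4-methoxyphenyl in place of 2-fluorophenyl on an amide-type nitrogen, which runs opposite to the change from compound 2 to compound 3. Because an at least 1.1-fold lower number from compound 2 to compound 3 (0.05 log units; that floor lies within the scatter) shows that moving to the 2-fluorophenyl lowered the number only by an unreadable floor, compound 4 is expected to return to the region of the limit, with an estimated value of 22000 nM (range 10000 nM to 45000 nM). The expected step is a 1.3-fold higher number from compound 3 to compound 4 (0.10 log units; within the scatter).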

Compound 4, half-maximal inhibitory concentration: > 20000 nM
Compound 4 ended at the assay's limit; the forecaster's own chance of this, stated with the estimate: 60%; the middle value is on the limit's open side.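

Within the data shown here, compound 4 brings an oxygen-bearing group onto the amide-type nitrogen for the first time, and against the only number in the set this gives an at least 1.1-fold higher number from compound 3 to compound 4 (0.05 log units; that floor lies within the scatter), so leaving the 2-fluorophenyl costs nothing that can be read. The steps joining compound 4 to compound 1 and to compound 2 cannot be read, as each has a limit at both ends. Methoxy in place of methylsulfanyl therefore produces no number in this assay, and with compound 3 as the one exception the set now stands as follows: the limit of > 20000 nM in this assay, at which 3 of the 4 values shown sit.

Going by these compounds, how far compound 1, compound 2 and compound 4 lie past that limit stays open. Equally open, on these data alone, is whether an amine or a carboxylic acid on this ring would give a readable number.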